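Swapping the aryl group on a triazole-bearing furanone scaffold

A few compounds are considered here, and "the series" means these few. Any claim that something is new, unique, unknown or untested is made for them only; others in the source may bear on it.

Compound 1 has the structure `COc1ccccc1-c1cn(C[C@H](O)[C@H]2OC(=O)C(OCc3ccccc3)=C2OCc2ccccc2)nn1`. In a functional assay on SW-620 cells (Homo sapiens) for antiproliferative activity, read by MTT assay, with a stated time of 72 h (on this read-out higher numbers stand for weaker inhibition and lower numbers for stronger inhibition), compound 1 gives only a limit, > 100000 nM, not a measured number. A second member of the series, compound 2 with the structure `O=C1O/C(=C\Cn2cc(-c3cc(C(F)(F)F)cc(C(F)(F)F)c3)nn2)C(OCc2ccccc2)=C1OCc1ccccc1`, is also known only by a limit: in this assay compound 2 gives > 100000 nM. Both values therefore sit at the same boundary of the assay, (the limit of > 100000 nM in this assay, at which 2 of the 2 values shown sit), so compound 1 stands where every other value shown stands, and no comparison between them can be drawn. Among the measured compounds shown here, no step between two measured compounds is available.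

The unmeasured compound 3 has the structure `Cc1ccc(-c2cn(C[C@H](O)[C@H]3OC(=O)C(OCc4ccccc4)=C3OCc3ccccc3)nn2)cc1`. It differs from compound 1 in one place: 4-methylphenyl in place of 2-methoxyphenyl on an aromatic carbon. With both measured compounds resting at a limit, there is no evidence that a change of this kind on the shared core moves the read-out at all, so a step of no more than the usual scatter, in either direction, is expected from compound 1 to compound 3, a step that the limit leaves unreadable from compound 1 to compound 3. In this assay compound 3 is expected to give about 150000 nM, within the range 40000 nM to 600000 nM, most likely again reported only as a limit.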

Compound 3, half-maximal inhibitory concentration: > 100000 nM
Compound 3 ended at the assay's limit; the forecaster's own chance of this, stated with the estimate: 85%; the middle value is on the limit's open side.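

In this assay, compound 3 and compound 1 are both known only by a limit, so no step can be read between them: the limit of > 100000 nM in this assay, at which 3 of the 3 values shown sit.

The compounds shown leave open whether any aryl group on the shared core gives a real number in this assay, and so how such groups would compare.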